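The source may hold more compounds than are shown below. What is called first, only, known or untested is meant among the compounds shown, and "the series" means these compounds.

Notes on the series. Among the compounds with values here, in a functional assay on CCRF-CEM cells (Homo sapiens) for antiproliferative activity, read by MTT assay, with a stated time of 24 h, tested at 100 uM (on this read-out higher numbers stand for a weaker effect at the one concentration tested and lower numbers for a stronger effect), compound 2 `COc1cccc(C(O)CCn2nc3c(Br)c(Br)c(Br)c(Br)c3n2)c1` gives 48%, the highest of the three numbers so far; compound 3 `C[C@@H](O)CCn1nc2c(Br)c(Br)c(Br)c(Br)c2n1` gives 36% and compound 1 `OC(CCn1nc2c(Br)c(Br)c(Br)c(Br)c2n1)c1cccc(Br)c1` gives 0%, both beyond the scatter below compound 2. Compound 4 `OC(CCn1nc2c(Br)c(Br)c(Br)c(Br)c2n1)c1ccccc1` differs from compound 2 by hydrogen in place of methoxy on an aromatic carbon. Within the data shown here, the only measured step at that position, a number 48 percentage points higher from compound 1 to compound 2 (beyond the scatter), shows that what sits on the phenyl ring moves the read-out by a large amount; hydrogen was not tested there, so direction must be interpolated between bromo and methoxy. A drop in this assay is therefore expected, the estimated step being a number 20 percentage points lower from compound 2 to compound 4 (beyond the scatter). For compound 4 the value in this assay is estimated at 28%, within 5% to 55%.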

Compound 4, a percentage reported as activity, at one concentration (the size of the read-out at that concentration, not a potency): 21%
Compound 4: middle estimate off by 7 percentage points, on the high side, within the range that was stated.
By their numbers in this assay, from the lowest: compound 1; then compound 4; then compound 3; then compound 2.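

Taking the methoxy away gives a number 27 percentage points lower from compound 2 to compound 4 (beyond the scatter), and taking the bromo away gives a number 21 percentage points higher from compound 1 to compound 4 (beyond the scatter), so the two groups move the number in opposite directions from hydrogen in this assay. Against the phenyl of compound 4, methoxy on this aromatic carbon therefore weakens the effect at the one concentration tested, and bromo strengthens it. Nothing available explains this order. Open, as far as these compounds go, is how an amine or a carboxylic acid on the same aromatic carbon would compare with hydrogen.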